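Methoxy to Chloro: What Compound 3 Might Show

A few compounds are considered here, and "the series" means these few. Any claim that something is new, unique, unknown or untested is made for them only; others in the source may bear on it.

Two measured compounds share one core. Compound 1 `Cc1ccc(S(=O)(=O)c2n[nH]c3ccc(N4CCN(C)CC4)cc23)cc1` carries a methyl, and in an assay on HeLa cells for displacement of a labelled ligand from 5-hydroxytryptamine receptor 6 (Homo sapiens) (a higher number here means a weaker inhibitor, a lower number a stronger inhibitor), compound 1 gives 4.9 nM. Among the compounds with values here, compound 2 `COc1ccc(S(=O)(=O)c2n[nH]c3ccc(N4CCN(C)CC4)cc23)cc1` carries a methoxy in its place, and in this assay compound 2 gives 12 nM, the higher of the two numbers; the only measured step, a 2.4-fold higher number from compound 1 to compound 2 (0.39 log units; beyond the scatter), records that change. Compound 3 `CN1CCN(c2ccc3[nH]nc(S(=O)(=O)c4ccc(Cl)cc4)c3c2)CC1` differs from compound 2 by chloro in place of methoxy on an aromatic carbon. Within the data shown here, no measured step covers chloro, and the only step available was modest, so compound 3 is expected to move modestly downward, a 2.0-fold lower number from compound 2 to compound 3 (0.30 log units; within the scatter). Compound 3 is therefore estimated at 6 nM, between 2.5 nM and 15 nM.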

Compound 3, inhibition constant: 8.1 nM
The estimate for compound 3 lay 1.4-fold (0.13 log units) below the measured number, and the stated range covers the measured number.
By their numbers in this assay, from the lowest: compounds 1, 3 and 2 (each within the scatter of the next, the first and the last beyond it).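

Chloro is tolerated at this position in this assay: the step of a 1.5-fold lower number from compound 2 to compound 3 (0.17 log units; within the scatter) and the step of a 1.7-fold higher number from compound 1 to compound 3 (0.22 log units; within the scatter) both stay small. Chloro, a single heavy atom with no hydrogen-bond acceptor, therefore cannot be told apart from either methoxy or methyl here, even though those two groups differ from each other beyond the scatter. Nothing available explains these numbers. From the compounds shown here alone, whether this position also tolerates an amine, a carboxylic acid or a longer chain remains open. So does whether a second halogen, such as bromo, would behave like chloro.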